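Swapping a Methoxy for Chloro on the Pendant Phenyl

The source may report more compounds than this note shows. Statements on the series, on what has been measured and on what is new or still open speak of the compounds shown alone.

Compound 1 `OC(CCn1nc2c(Br)c(Br)c(Br)c(Br)c2n1)c1ccc(F)cc1`: 88%
Compound 2 `COc1cccc(C(O)CCn2nc3c(Br)c(Br)c(Br)c(Br)c3n2)c1`: 50%

Of the compounds shown here, two sharing the same brominated core have been measured in a functional assay on CCRF-CEM cells (Homo sapiens) for antiproliferative activity, read by MTT assay, with a stated time of 48 h, tested at 25 uM; a lower number here means a stronger effect, a higher number a weaker effect of the compound at the concentration tested. Compound 1 gives 88%, while compound 2 gives 50%. Among the compounds with values here, the single change between them, 3-methoxyphenyl in place of 4-fluorophenyl on a saturated chain carbon bound to an oxygen on a saturated carbon and a saturated chain carbon, brings a number 38 percentage points lower from compound 1 to compound 2 (beyond the scatter). Compound 2 therefore stands as the lower of the two numbers, with compound 1 well above it.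

Compound 3 `OC(CCn1nc2c(Br)c(Br)c(Br)c(Br)c2n1)c1cccc(Cl)c1` has not yet been measured. It differs from compound 2 by chloro in place of methoxy on an aromatic carbon. Within the data shown here, no measured step concerns a chloro in place of a methoxy, and the one step known here changed both the group and its position at once, so it does not directly bear on this swap. The expectation is therefore uncertain: a step of a number 10 percentage points higher from compound 2 to compound 3 (within the scatter) is estimated, with no clear direction beyond the scatter. Compound 3 is expected to give about 60%, within a range from 35% to 88%.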

Compound 3, a percentage reported as activity, at one concentration (the size of the read-out at that concentration, not a potency): 68%
The estimate for compound 3 lay 8 percentage points below the measured number, and the stated range covers the measured number.
By their numbers in this assay, from the lowest: compound 2; then compound 3; then compound 1.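

The earlier pair changed the group and its place on the ring together, but here the place stays the same: on an aromatic carbon of the six-membered ring, meta to a large group. In this assay, chloro in place of methoxy brings a number 18 percentage points higher from compound 2 to compound 3 (beyond the scatter) with nothing else altered, so the choice of group at this position matters in its own right, and of these two the methoxy of compound 2 goes with the stronger effect. The step to the other halogen-bearing compound, a number 20 percentage points lower from compound 1 to compound 3 (beyond the scatter) as 3-chlorophenyl replaces 4-fluorophenyl, shows that carrying a halogen on this ring does not by itself settle the number, although the halogen and its place change together there, so neither can be credited alone; nothing measured here says what lies behind either step.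

Three compounds cannot show whether chloro at the place held by fluoro in compound 1, or fluoro at the place held by chloro in compound 3, would separate those two changes. Also open, on these data alone, is how this position would respond to quite different groups, such as an amine, a carboxylic acid or a longer chain in place of methoxy or chloro.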